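This account rests on a few compounds, and the source may have more. Where it says the series, first, only, none or still open, it means among the compounds named here.

Measured compounds and their values:
Compound 1, `CCCCCCCCCCCCCC[C@H]1N[C@@H](CO)[C@@H]1O`: 0.17 ug/mL
Compound 2, `CCCCCCCCCCCCCC[C@H]1N[C@H](CO)[C@H]1O`: 1.23 ug/mL

In a functional assay on HT529 cells (Homo sapiens) for cytotoxicity (a higher number here means a weaker inhibitor, a lower number a stronger inhibitor), compound 1 gives the lowest of the two numbers shown, so it is the stronger inhibitor of the pair. Within the data shown here, its only neighbour is compound 2, reached by a 7.2-fold higher number from compound 1 to compound 2 (0.86 log units; beyond the scatter). That step rests on (the fact that compounds 1 and 2 differ only in the configuration as drawn), so here a change of drawn configuration alone moved the number by a modest but real amount.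

Compound 3, `CCCCCCCCCCCCCC[C@H]1N[C@@H](CO)[C@H]1O`, has not yet been measured in this assay. It differs from compound 1 as follows: the two compounds have the same atoms and bonds and differ only in configuration as drawn: 1 of 3 stereo elements differ; a stereocentre at a saturated ring carbon is drawn R in compound 1 and S in compound 3. Among the measured compounds shown here, this is a change of the same kind as the one from compound 1 to compound 2, but smaller, since fewer stereo elements are altered. For the measured compounds named here, the single measured step of this kind, a 7.2-fold higher number from compound 1 to compound 2 (0.86 log units; beyond the scatter), was modest and weakening, so a weakening step is expected here too, probably smaller than that one. Compound 3 is therefore expected to give 0.5 ug/mL, with a range from 0.15 ug/mL to 1.5 ug/mL. This expectation corresponds to a 2.9-fold higher number from compound 1 to compound 3 (0.47 log units; beyond the scatter).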

Compound 3, half-maximal inhibitory concentration: 1.65 ug/mL
For compound 3 the middle estimate is 3.3-fold (0.52 log units) below the measured one; measured number above the stated range.
By their numbers in this assay, from the lowest: compound 1; then compounds 2 and 3 (each within the scatter of the next).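

In this assay, altering just one of the three stereo elements of compound 1 already gives a 9.7-fold higher number from compound 1 to compound 3 (0.99 log units; beyond the scatter), so a single stereocentre at a saturated ring carbon is enough for a clear loss, and this step rests on one plain fact: the fact that compounds 1 and 3 differ only in the configuration as drawn. Compound 2 could show only that two altered elements together mattered, whereas compound 3 ties a change of this size to one centre. The remaining stereo difference between the two altered compounds makes no readable change in this assay, where the comparison gives a 1.3-fold higher number from compound 2 to compound 3 (0.13 log units; within the scatter), a step within the scatter that again involves configuration alone: the fact that compounds 2 and 3 differ only in the configuration as drawn.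

Among these compounds, what that remaining centre does on its own, with the other centre left as drawn in compound 1, stays open, since here it is seen only in compounds where the other centre is already altered. Also open, from the compounds shown here alone, is whether the low number of compound 1 would survive a longer chain, or an amine or a carboxylic acid in place of the hydroxyl group.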